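Cytotoxicity of a heteroaryl swap on the pyrrolidinone ring

The source may hold more compounds than are shown below. What is called first, only, known or untested is meant among the compounds shown, and "the series" means these compounds.

Measured compounds:
- compound 1, `O=C1CC(Oc2ncc(F)cn2)CN1c1cnn2c1CN(C(=O)Nc1cc(F)c(F)c(F)c1)C(C1CC1)C2`: 96200 nM
- compound 2, `O=C1CC(c2ccc(F)cc2)CN1c1cnn2c1CN(C(=O)Nc1cc(F)c(F)c(F)c1)C(C1CC1)C2`: 32100 nM
- compound 3, `C[C@H]1Cn2ncc(N3CC(c4ccccc4)CC3=O)c2CN1CC(=O)Nc1cc(F)c(F)c(F)c1`: > 2000 nM

In a toxicity assay on HepG2 2.2.15 cells (Homo sapiens) for cytotoxicity, read by CellTiter-Glo (a higher number here means that more compound is tolerated, a lower number that less compound is tolerated), compound 2 has the lowest of the two numbers, the nearest being compound 1 with a 3.0-fold lower number from compound 1 to compound 2 (0.48 log units; beyond the scatter). The value of compound 3 in this assay is a limit of the assay, not a number (the limit of > 2000 nM in this assay, at which 1 of the 3 values shown sits). Compound 4, `Cc1cnc(C2CC(=O)N(c3cnn4c3CN(C(=O)Nc3cc(F)c(F)c(F)c3)C(C3CC3)C4)C2)s1`, has not yet been measured in this assay. It differs from compound 2 by 5-methyl-1,3-thiazol-2-yl in place of 4-fluorophenyl on a saturated ring carbon. Among the measured compounds shown here, the only measured step at this position is a 3.0-fold lower number from compound 1 to compound 2 (0.48 log units; beyond the scatter), which was modest; it exchanged an aryl ether for an aryl ring, whereas compound 4 exchanges one aromatic ring for another at the same place. For the measured compounds named here, no measured pair shows exactly this kind of change, so no clear direction follows; a step within the scatter, or a modest rise toward the number of compound 1, is expected. Compound 4 is therefore estimated at 45000 nM, with a range from 15000 nM to 120000 nM, meaning an expected 1.4-fold higher number from compound 2 to compound 4 (0.15 log units; within the scatter).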

Compound 4, half-maximal cytotoxic concentration: 96200 nM
Beside the measured number, compound 4's estimate is 2.1-fold (0.33 log units) below it; the range from low to high includes it.
By their numbers in this assay, from the lowest: compound 2; then compounds 1 and 4 (each within the scatter of the next).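

In this assay, 5-methyl-1,3-thiazol-2-yl in place of 4-fluorophenyl gives a 3.0-fold higher number from compound 2 to compound 4 (0.48 log units; beyond the scatter), so exchanging one aromatic ring for another on this saturated ring carbon also moves the number, as the earlier exchange of an aryl ether for an aryl ring did. The (5-fluoropyrimidin-2-yl)oxy and 5-methyl-1,3-thiazol-2-yl groups show no change at the digits printed from compound 1 to compound 4 (within the scatter), which leaves compound 2, with its 4-fluorophenyl, alone at the lowest of the three numbers at this place. Nothing shown here accounts for this difference.

The compounds shown leave open whether an amine or a carboxylic acid on this carbon would stay level with compound 1 and compound 4 or come closer to compound 2. Among the compounds shown here, they also leave open what the methyl contributes, as no pair separates it from the thiazole ring.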